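This account rests on a few compounds, and the source may have more. Where it says the series, first, only, none or still open, it means among the compounds named here.

Compound 1 `CC1=CC[C@@H]([C@@](C)(O)CCCC(C)(C)NC(=S)N/N=C\c2ccccc2)CC1`: 8470 nM
Compound 2 `CC1=CC[C@@H]([C@@](C)(O)CCCC(C)(C)NC(=S)N/N=C\c2ccc(C)cc2)CC1`: 6750 nM

In a functional assay on PCO3 cells (Homo sapiens) for cytotoxicity, read by sulforhodamine B assay (a lower number here means a stronger inhibitor of growth, a higher number a weaker inhibitor of growth), compound 2 stands at 6750 nM. Compound 1 gives 8470 nM in this assay, and the step of a 1.3-fold lower number from compound 1 to compound 2 (0.10 log units; within the scatter) lies within the scatter, so the two compounds cannot be told apart on these numbers. Compound 3 `COc1ccc(/C=N\NC(=S)NC(C)(C)CCC[C@](C)(O)[C@@H]2CC=C(C)CC2)cc1` has not yet been measured. It differs from compound 2 in one place: methoxy in place of methyl on an aromatic carbon. Among the measured compounds shown here, the only measured step that touches this site is a 1.3-fold lower number from compound 1 to compound 2 (0.10 log units; within the scatter), which placed a methyl on that same aromatic carbon and moved the number by no more than the scatter. For the measured compounds named here, no measured pair exchanges methyl for methoxy, so there is no direct precedent for this change. On the evidence available, no step beyond the scatter is expected in this assay, and the expected change is a 1.0-fold lower number from compound 2 to compound 3 (0.02 log units; within the scatter). Compound 3 is therefore estimated at 6500 nM, with an expected range from 2500 nM to 17000 nM.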

Compound 3, concentration for 50% growth inhibition: 7660 nM
Beside the measured number, compound 3's estimate is 1.2-fold (0.07 log units) below it, and the stated range covers the measured number.
By their numbers in this assay, from the lowest: compounds 2, 3 and 1 (each within the scatter of the next).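

In this assay the exchange of 4-methylphenyl for 4-methoxyphenyl gives a 1.1-fold higher number from compound 2 to compound 3 (0.05 log units; within the scatter) and putting methoxy in place of hydrogen gives a 1.1-fold lower number from compound 1 to compound 3 (0.04 log units; within the scatter) so hydrogen, methyl and methoxy at this aromatic carbon cannot be told apart. The earlier compounds shown here showed this only for methyl, whereas methoxy adds an oxygen and a hydrogen-bond acceptor to the same spot and the reading of growth inhibition in these cells still stays within the scatter. No measurement is available to explain this flat result.

The compounds shown leave open whether any group on this carbon can move the number beyond the scatter. An amine, a carboxylic acid or a longer chain such as butoxy in this place would put that question to the test.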